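Methyl in Place of Chloro on the Phenyl Ring

A few compounds are considered here, and "the series" means these few. Any claim that something is new, unique, unknown or untested is made for them only; others in the source may bear on it.

Compound 1 `CCNC(=O)c1oc2nc(-c3ccccc3)cc(C(F)(F)F)c2c1N` and compound 2 `Nc1c(C(=O)N/N=C/c2ccc(Cl)cc2)oc2nc(-c3ccccc3)cc(C(F)(F)F)c12` have both been tested in a functional assay on HepG2 cells (Homo sapiens) for antiproliferative activity, read by MTT assay; a lower number here means a stronger inhibitor, a higher number a weaker inhibitor. Compound 1 gives 42800 nM and compound 2 gives 12100 nM, the lower of the two numbers; the step of a 3.5-fold lower number from compound 1 to compound 2 (0.55 log units; beyond the scatter). Compound 3 `Cc1ccc(/C=N/NC(=O)c2oc3nc(-c4ccccc4)cc(C(F)(F)F)c3c2N)cc1` differs from compound 2 by methyl in place of chloro on an aromatic carbon. Within the data shown here, the single measured step concerns another part of the molecule, so no step bears directly on this change, and nothing here points in either direction. Compound 3 is therefore expected to show a step of a 1.0-fold lower number from compound 2 to compound 3 (0.00 log units; within the scatter) that stays within the scatter. The estimate for compound 3 is 12000 nM, with a range from 5000 nM to 30000 nM.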

Compound 3, half-maximal inhibitory concentration: 8900 nM
Compound 3: the middle estimate sits 1.3-fold (0.13 log units) above what was measured; the measured number falls inside the stated range.
By their numbers in this assay, from the lowest: compounds 3 and 2 (each within the scatter of the next); then compound 1.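

In this assay, methyl in place of chloro on the aromatic carbon para to a large group gives a 1.4-fold lower number from compound 2 to compound 3 (0.13 log units; within the scatter), so at this position the two groups cannot be told apart. With methyl, the larger group on the amide-type nitrogen still reads better than the two-carbon group, with a 4.8-fold lower number from compound 1 to compound 3 (0.68 log units; beyond the scatter), as it did with chloro. Nothing measured here accounts for this result. Going by these compounds, whether a methoxy, a hydroxyl or an amine at this place would read the same stays open, as does the effect of methyl elsewhere on this ring.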